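A few compounds are considered here, and "the series" means these few. Any claim that something is new, unique, unknown or untested is made for them only; others in the source may bear on it.

Compound 1 `Cn1nccc1-c1cccc2c1CCC2c1ncc[nH]1`: > 10000 nM
Compound 2 `Cn1cc(-c2cccc3c2CCC3c2ncc[nH]2)cn1`: > 10000 nM

Both compounds share a core that carries an imidazole and a methylated pyrazole, and both were tested in a functional assay on CHO cells for agonist activity at Alpha-1B adrenergic receptor (Homo sapiens), read by FLIPR and calcium flux; on this read-out lower numbers stand for an effect already at smaller amounts and higher numbers for an effect only at larger amounts of compound. For compound 1 the value > 10000 nM is a limit of this assay rather than a number. For compound 2 the value > 10000 nM is likewise a limit of this assay. Among the compounds with values here, compound 2 therefore stands at the edge of what this assay can report, and the single measured step, a step that the two limits leave unreadable from compound 1 to compound 2, cannot be read in size or direction because both values sit at the limit of > 10000 nM in this assay, at which 2 of the 2 values shown sit.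

Compound 3 `c1cc(-c2cn[nH]c2)c2c(c1)C(c1ncc[nH]1)CC2` has not been measured. It differs from compound 2 by hydrogen in place of methyl on an aromatic nitrogen. Within the data shown here, no measured step bears on this change, and the one step available is itself unreadable, so nothing in the data points to a move away from the limit. Compound 3 is therefore expected to give 20000 nM, with a range from 3000 nM to 100000 nM, most likely again a limit. The expected step is a step that the limit leaves unreadable from compound 2 to compound 3, with no direction beyond the scatter that can be supported.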

Compound 3, half-maximal effective concentration: > 10000 nM
Compound 3: a limit, no number; the forecaster's own chance of this, stated with the estimate: 85%; the middle value lies beyond the limit too.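

In this assay, no step among compound 1, compound 2 and compound 3 can be read, in size or in direction: the limit of > 10000 nM in this assay, at which 3 of the 3 values shown sit.

The compounds shown leave open whether any change to the pyrazole on the shared core could bring a measurable effect, and how far each compound lies beyond that limit.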